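Branching the propyl chain in a thienyl/furyl dihydropyrimidinone series

A few compounds are considered here, and "the series" means these few. Any claim that something is new, unique, unknown or untested is made for them only; others in the source may bear on it.

Compound 1 `CCCOC(=O)C1=C(C)NC(=O)NC1c1cccs1` and compound 2 `CC1=C(C(=O)OCC(C)C)C(c2cccs2)NC(=O)N1` share one core; compound 3 `CCCC(=O)C1=C(C)NC(=O)NC1c1ccco1` and compound 4 `CC1=C(C(=O)CC(C)C)C(c2ccco2)NC(=O)N1` share another. The difference between the two cores is not broken down here.

In an assay on membranes from HEK293 cells for displacement of a labelled ligand from adenosine receptor A2b (Homo sapiens), read by scintillation counting, with a stated time of 30 min (on this read-out lower numbers stand for stronger inhibition and higher numbers for weaker inhibition), compound 1 gives 1520 nM. Compound 2 gives 2130 nM. Compound 3 gives 807 nM. The two values of compound 1 and compound 3 lie within the scatter of each other, so no order between them is drawn.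

The change from compound 1 to compound 2 is methyl in place of hydrogen on a saturated chain carbon bound to two saturated chain carbons and gives a 1.4-fold higher number from compound 1 to compound 2 (0.15 log units; within the scatter). The change from compound 3 to compound 4 is methyl in place of hydrogen on a saturated chain carbon bound to two saturated chain carbons. The two place lines read the same word for word, and the change is the same kind of change; the longer readings differ only in the group the chain hangs on, a propoxy in the first pair and a propylcarbonyl in the second.

Among the compounds with values here, for compound 4 the step is expected to be of about the size seen in the first pair, because a 1.4-fold higher number from compound 1 to compound 2 (0.15 log units; within the scatter) was within the scatter; the single earlier instance of the change is thin ground, so a wide range is kept. The expected step from compound 3 to compound 4 is a 1.4-fold higher number from compound 3 to compound 4 (0.13 log units; within the scatter). Compound 4 is estimated at 1100 nM, with a range from 450 nM to 2700 nM in this assay.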

Compound 4, inhibition constant: 240 nM
Beside the measured number, compound 4's estimate is 4.6-fold (0.66 log units) above it, outside the stated range (below it).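

In this assay the methyl-for-hydrogen change on the saturated chain carbon does not carry over from one core to the other at a fixed size. On the core of compound 3 it reads as a 3.4-fold lower number from compound 3 to compound 4 (0.53 log units; beyond the scatter), and the two instances differ in direction as well as size: the same change on two cores in this assay, a 1.4-fold higher number (0.15 log units; within the scatter) from compound 1 to compound 2 and a 3.4-fold lower number (0.53 log units; beyond the scatter) from compound 3 to compound 4, 4.7-fold (0.67 log units) apart, beyond the scatter of two such steps. For this series, a step read on the core of compound 1 is therefore a poor guide to the same change on the core of compound 3, and the reverse holds too. This does not show which part of the structure sets the gap, as the two pairs differ both in the group the chain hangs on, propoxy against propylcarbonyl, and in the rest of the core, and with a single pair on each core neither step can be called typical of that core.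

The compounds shown leave open whether the step follows the carbonyl-linked chain or the remaining part of the core, as no pair keeps one fixed while the other changes. Also open, from the compounds shown here alone, is how a longer chain such as pentyl, or a tert-butyl group, would read in the same assay on either core.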